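Replacing cyclohexylamino with methoxy on a shared core

The compounds below may be only part of what the source reports. "The series", "measured", "known", "first", "only" and "open" are said of these compounds alone.

In a functional assay on HeLa cells (Homo sapiens) for antiproliferative activity, read by WST assay, with a stated time of 24 h (on this read-out lower numbers stand for stronger inhibition and higher numbers for weaker inhibition), compound 1 (`C=C[C@]1(C)CC[C@@H](C(=C)CNCCCC)C[C@H]1C(=C)C`) gives 10800 nM and compound 2 (`C=C[C@]1(C)CC[C@@H](C(=C)CNC2CCCCC2)C[C@H]1C(=C)C`) gives 3390 nM, the lower of these two numbers. Changing butyl to cyclohexyl on the amine nitrogen produces a 3.2-fold lower number from compound 1 to compound 2 (0.50 log units; beyond the scatter), a modest step but beyond the scatter. Compound 3 (`C=C[C@]1(C)CC[C@@H](C(=C)COC)C[C@H]1C(=C)C`) has methoxy in place of cyclohexylamino on a saturated chain carbon bound to a double-bonded chain carbon. Among the measured compounds shown here, no measured compound lacks the amine, so this one step is only a loose guide. Still, the cyclohexyl compound has the lower number, and compound 3 loses that ring, so a move to a higher number in this assay is expected, somewhat larger than the measured step. The estimated change is a 5.9-fold higher number from compound 2 to compound 3 (0.77 log units; beyond the scatter). For compound 3 the estimated value is 20000 nM, with an expected range of 7000 nM to 60000 nM.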

Compound 3, half-maximal inhibitory concentration: 212000 nM
Compound 3: middle estimate off by 11-fold (1.03 log units), on the low side, outside the stated range (above it).
By their numbers in this assay, from the lowest: compound 2; then compound 1; then compound 3.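

In this assay, compound 3 shows that this place on the chain is far more sensitive to change than the two amines suggested: methoxy in place of cyclohexylamino gives a 63-fold higher number from compound 2 to compound 3 (1.80 log units; beyond the scatter), and methoxy in place of butylamino gives a 20-fold higher number from compound 1 to compound 3 (1.29 log units; beyond the scatter). Both steps are larger than the one between the two amines, a 3.2-fold lower number from compound 1 to compound 2 (0.50 log units; beyond the scatter), so removing the whole amine group changes the number more than swapping the group on its nitrogen. Nothing available explains the size of this rise.

Methoxy removes both the amine nitrogen and the butyl or cyclohexyl group on it, so the compounds shown cannot tell which loss matters more. A cyclohexyloxy group or a plain amino group at this place could separate the two.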